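Replacing the Dimethoxybenzoyl Group on a Weak Inhibitor

The source may hold more compounds than are shown below. What is called first, only, known or untested is meant among the compounds shown, and "the series" means these compounds.

compound 1 `Cc1cc(C)cc(C(=O)N(CCC(=O)NCc2ccccc2)Cc2ccc(C(=O)NO)cc2)c1`: 1390 nM
compound 2 `COc1cc(OC)cc(C(=O)N(CCC(=O)NCc2ccccc2)Cc2ccc(C(=O)NO)cc2)c1`: 6040 nM
compound 3 `Cc1ccc(NC(=O)CCN(Cc2ccc(C(=O)NO)cc2)C(=O)c2ccc(N(C)C)cc2)cc1`: 300 nM

All three values come from a functional assay on IMR-32 cells (Homo sapiens) for antiproliferative activity, with a stated time of 72 h; a higher number here means a weaker inhibitor, a lower number a stronger inhibitor. Compound 2, at 6040 nM, has the highest number of the three, making it the weakest inhibitor so far. Compound 4 `COc1ccc(C(=O)N(CCC(=O)NCc2ccccc2)Cc2ccc(C(=O)NO)cc2)cc1` carries 4-methoxyphenyl in place of 3,5-dimethoxyphenyl on a carbonyl carbon. Among the measured compounds shown here, one measured step bears on this place: a 4.3-fold higher number from compound 1 to compound 2 (0.64 log units; beyond the scatter), a modest change that came with the arrival of 3,5-dimethoxyphenyl. For the measured compounds named here, no measured compound carries 4-methoxyphenyl, so the evidence is thin. A modest move to a lower number is expected in this assay, namely a 2.4-fold lower number from compound 2 to compound 4 (0.38 log units; beyond the scatter). The estimate for compound 4 is 2500 nM, with an expected range of 900 nM to 6500 nM.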

Compound 4, half-maximal inhibitory concentration: 1090 nM
Compound 4: middle estimate off by 2.3-fold (0.36 log units), on the high side; measured number inside the range.
By their numbers in this assay, from the lowest: compound 3; then compounds 4 and 1 (each within the scatter of the next); then compound 2.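

In this assay, this place on the carbonyl carbon responds clearly to 4-methoxyphenyl in place of 3,5-dimethoxyphenyl, and the number falls (a 5.5-fold lower number from compound 2 to compound 4 (0.74 log units; beyond the scatter)). Against 3,5-dimethylphenyl, 4-methoxyphenyl makes no real difference (a 1.3-fold lower number from compound 1 to compound 4 (0.11 log units; within the scatter)), so among these three groups only 3,5-dimethoxyphenyl stands apart, with the highest number. Nothing available explains this difference.

The compounds shown leave open whether the methoxy group is needed here at all, since plain phenyl is not among them. As far as these compounds go, how a carboxylic acid or an amine on this ring would behave on the same core also remains open.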